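Side-chain truncation across two cores, tail flick expectation

The source may report more compounds than this note shows. Statements on the series, on what has been measured and on what is new or still open speak of the compounds shown alone.

Measured in a functional assay on the whole organism (Tail, strain ICR) with Mus musculus as the target, in the tail flick test, with a stated time of 60 min, at a dose of 25 umol/kg by the oral route; a higher number here means a stronger effect of the compound at the dose given, a lower number a weaker effect:
compound 1, `O=C(CN(c1ncnc2c1ncn2C1CCCCO1)C1CC1)NCC(=O)OCc1ccccc1`, gives 40.4%.
compound 2, `NC(=O)C[C@H](NC(=O)CN(c1ncnc2c1ncn2C1CCCCO1)C1CC1)C(=O)OCc1ccccc1`, gives 30.5%.
compound 3, `NC(=O)CC[C@H](NC(=O)CN(c1nc(Cl)nc2[nH]cnc12)C1CC1)C(=O)O`, gives 38.4%.

Compound 4, `C[C@H](NC(=O)CN(c1nc(Cl)nc2[nH]cnc12)C1CC1)C(=O)O`, is not yet measured in this assay. It differs from compound 3 by hydrogen in place of carbamoylmethyl on a saturated chain carbon, two bonds along the chain from an amide-type nitrogen and a carbonyl carbon. The same kind of change, though not the same one, is already measured between compound 2 and compound 1: hydrogen in place of carbamoylmethyl on a saturated chain carbon bound to an amide-type nitrogen and a carbonyl carbon. In the measured pair the leaving group sits on a saturated chain carbon bound to an amide-type nitrogen and a carbonyl carbon; in the new pair it sits two bonds along the chain from an amide-type nitrogen and a carbonyl carbon. The step it made there is a number 9.9 percentage points higher from compound 2 to compound 1 (within the scatter). The difference between the two cores, compound 2 against compound 3, is not broken down here. Among the measured compounds shown here, compound 3 and compound 1 lie within the scatter of each other, as do compound 3 and compound 2, so the three numbers so far offer no separation to build on. The step expected from this change is a number 3.6 percentage points higher from compound 3 to compound 4 (within the scatter), resting on the earlier a number 9.9 percentage points higher from compound 2 to compound 1 (within the scatter), which stayed within the scatter. Compound 4 is estimated at 42% in this assay, with a range from 28% to 56%.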

Compound 4, a percentage reported as activity, at one dose (the size of the read-out at that dose, not a potency): 44.6%
Beside the measured number, compound 4's estimate is 2.6 percentage points below it; the range from low to high includes it.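

In this assay, replacing the chain carrying the carbamoyl group with a shorter one gives a number 6.2 percentage points higher from compound 3 to compound 4 (within the scatter), the step named by the change from 2-carbamoylethyl to methyl. Set beside the earlier step, the change reads alike on both cores: the same change on two cores in this assay, a number 9.9 percentage points higher (within the scatter) from compound 2 to compound 1 and a number 6.2 percentage points higher (within the scatter) from compound 3 to compound 4, 3.7 percentage points apart, within the scatter of two such steps

Among the compounds shown here, both steps stay within the scatter, so this agreement shows only that the two cores give no sign of responding differently to the change; it does not show that the change raises the read-out on either core, nor does a single read-out at one dose and one time say anything about potency, and two pairs are too few to establish a rule for the series.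

Other side chains at this place remain open, for example an amine, a hydroxyl or a longer chain ending in a carboxylic acid. Going by these compounds, the effect of the core alone also stays open, as the compounds on the two cores differ in more than one place.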